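The source may report more compounds than this note shows. Statements on the series, on what has been measured and on what is new or still open speak of the compounds shown alone.

Measured in a functional assay on MOLT-4 cells (Homo sapiens) for inhibition, read by MTT assay, with a stated time of 72 h; on this read-out lower numbers stand for stronger inhibition and higher numbers for weaker inhibition:
- compound 1 `COc1cc(NC(C)CCCNC(=O)NNC(=O)Nc2ccc(F)cc2)c2ncccc2c1`: >= 250000 nM
- compound 2 `COc1cc(NC(C)CCCNC(=O)NNC(=O)Nc2ccc(Cl)cc2)c2ncccc2c1`: 186000 nM

Within the data shown here, compound 2 gives 186000 nM, the only actual number so far. Compound 1 gives >= 250000 nM, which is a limit of this assay and not a number.

Compound 3 `COc1cc(NC(C)CCCNC(=O)NNC(=O)Nc2ccc(C(F)(F)F)cc2)c2ncccc2c1` differs from compound 2 by one change: trifluoromethyl in place of chloro on an aromatic carbon. Trifluoromethyl stands in place of chloro on an aromatic carbon, para to a large group. Among the measured compounds shown here, the one measured step that bears on this swaps a group at that same carbon, chloro in place of fluoro, and it is an at least 1.3-fold lower number from compound 1 to compound 2 (0.12 log units; that floor lies within the scatter). For the measured compounds named here, with only that small step as a guide, no change beyond the scatter is expected in this assay. The expected step is a 1.4-fold lower number from compound 2 to compound 3 (0.16 log units; within the scatter). Compound 3 is estimated at 130000 nM, with an expected range of 45000 nM to 250000 nM.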

Compound 3, half-maximal inhibitory concentration: 24000 nM
Estimate against measurement, compound 3: 5.4-fold (0.73 log units) above; measured number below the stated range.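

Trifluoromethyl in place of chloro gives a 7.8-fold lower number from compound 2 to compound 3 (0.89 log units; beyond the scatter) in this assay, so the group on this aromatic carbon can move the number beyond the scatter, which the step from fluoro to chloro did not show. Trifluoromethyl in place of fluoro gives an at least 10-fold lower number from compound 1 to compound 3 (1.01 log units; beyond the scatter). Compound 1 stands at a limit and not at a number, so that step is only a floor: the limit of >= 250000 nM in this assay, at which 1 of the 3 values shown sits.

Only fluoro, chloro and trifluoromethyl appear at this carbon, and these three cannot tell what about trifluoromethyl counts. A nitrile or a methoxy group there would show whether the drop is particular to trifluoromethyl.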